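The source may report more compounds than this note shows. Statements on the series, on what has been measured and on what is new or still open speak of the compounds shown alone.

Measured compounds:
compound 1, `CCOC(=O)C[C@H]1[C@@H](O[Si](C)(C)C(C)(C)C)[C@H](n2cnc3c(NC(=O)Nc4ccccc4)ncnc32)O[C@@H]1COC(=O)NC`, gives 6.37 nM;
compound 2, `CNC(=O)NC[C@H]1O[C@@H](n2cnc3c(NC(=O)Nc4ccccc4)ncnc32)[C@H](O[Si](C)(C)C(C)(C)C)[C@@H]1CC(=O)N(C)OC`, gives 15.2 nM.

In a functional assay on M14 cells (Homo sapiens) for antiproliferative activity (a lower number here means a stronger inhibitor of growth, a higher number a weaker inhibitor of growth), compound 2 holds the highest of the two numbers, and its nearest neighbour, compound 1, sits at a gap beyond the scatter. Compound 3, `CCOC(=O)C[C@H]1[C@@H](O[Si](C)(C)C(C)(C)C)[C@H](n2cnc3c(NC(=O)Nc4ccccc4)ncnc32)O[C@@H]1CNC(=O)NC`, is not yet measured. It differs from compound 2 in one place: ethoxy in place of methoxy(methyl)amino on a carbonyl carbon. Within the data shown here, no measured pair shows this change on its own, so its size is an expectation only. Compound 3 is expected to sit somewhat lower than compound 2, a step of a 1.7-fold lower number from compound 2 to compound 3 (0.23 log units; within the scatter), and its estimated value is 9 nM, within 3.5 nM to 25 nM.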

Compound 3, concentration for 50% growth inhibition: 2.51 nM
Beside the measured number, compound 3's estimate is 3.6-fold (0.55 log units) above it; measured number below the stated range.
By their numbers in this assay, from the lowest: compound 3; then compound 1; then compound 2.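

In this assay the exchange of methoxy(methyl)amino for ethoxy on a carbonyl carbon gives a 6.1-fold lower number from compound 2 to compound 3 (0.78 log units; beyond the scatter) and so can now be read on its own. On a saturated chain carbon bound to a saturated ring carbon, (methylcarbamoyl)amino in place of (methylcarbamoyl)oxy gives a 2.5-fold lower number from compound 1 to compound 3 (0.40 log units; beyond the scatter) and leaves compound 3 as the most potent of the three. Nothing measured here accounts for either step.

As far as these compounds go, it remains open how an amine or a hydroxyl on that carbonyl carbon, giving an amide or a carboxylic acid, would read. From the compounds shown here alone, a longer chain in place of ethoxy is equally open.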